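Fluoropyridinyl replacements on the alkyne terminus

The source may hold more compounds than are shown below. What is called first, only, known or untested is meant among the compounds shown, and "the series" means these compounds.

Compound 1 `C[C@@H](NC(=O)c1ccc(C#Cc2ccc(F)cc2F)cn1)C(C)(C)O` is the starting point of these notes. Going by the values given here, in a functional assay on HEK293 cells for positive allosteric modulation of metabotropic glutamate receptor 5 (Rattus norvegicus), read by fluorescence and calcium flux (a higher number here means a larger maximal response, a lower number a smaller maximal response), compound 1 gives 61.2%, the lower of the two numbers measured so far; its only neighbour is compound 2 `C[C@@H](NC(=O)c1ccc(C#Cc2ccc(F)cn2)cn1)C(C)(C)O`, which in this assay gives 64.6%, and the step of a number 3.4 percentage points higher from compound 1 to compound 2 (within the scatter) lies within the scatter, so no order between the two can be read from it. Compound 3 `C[C@@H](NC(=O)c1ccc(C#Cc2cc(F)ccn2)cn1)C(C)(C)O` has not yet been measured. It differs from compound 1 in one place: 4-fluoropyridin-2-yl in place of 2,4-difluorophenyl on a triple-bonded carbon. Among the compounds with values here, the only measured step that bears on this change is a number 3.4 percentage points higher from compound 1 to compound 2 (within the scatter), where a fluoropyridinyl group likewise replaced the 2,4-difluorophenyl on the triple-bonded carbon and the maximal response did not move beyond the scatter. Nothing in the series points to a larger effect for the 4-fluoropyridin-2-yl variant, so for compound 3 a step of a number 1.8 percentage points higher from compound 1 to compound 3 (within the scatter) is expected, that is, no change beyond the scatter. The estimated value for compound 3 in this assay is 63%, with a range from 50% to 77%.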

Compound 3, largest response reached (reported as efficacy), in percent of the reference or control that the assay uses: 66.2%
The estimate for compound 3 lay 3.2 percentage points below the measured number; measured number inside the range.
By their numbers in this assay, from the lowest: compounds 1, 2 and 3 (each within the scatter of the next).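

In this assay, the step for 4-fluoropyridin-2-yl on the triple-bonded carbon is a number 5 percentage points higher from compound 1 to compound 3 (within the scatter), so a second fluoropyridinyl group can take the place of 2,4-difluorophenyl without separating from it in maximal response. The exchange of 5-fluoropyridin-2-yl for 4-fluoropyridin-2-yl adds a comparison that the earlier pair could not give: the step is a number 1.6 percentage points higher from compound 2 to compound 3 (within the scatter), so this read-out does not distinguish the two fluoropyridinyl groups at this position. No supporting information bears on why the three groups read alike.

All three groups at this position are fluorine-bearing six-membered aromatic rings, so it remains open whether an unsubstituted pyridin-2-yl, a pyrimidin-2-yl or a saturated cyclohexyl group on the triple-bonded carbon would stay within the scatter of these compounds. Also open, on these data alone, is whether compound 1, compound 2 and compound 3 differ in the concentration needed to reach this response, since a shared maximal response says nothing on that point.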